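Diethylamino in Place of 4-Methylpiperazin-1-yl: Expected Outcome

This account rests on a few compounds, and the source may have more. Where it says the series, first, only, none or still open, it means among the compounds named here.

Compound 1 `C#Cc1cccc(Nc2ncnc3ccc(NC(=O)Nc4ccc(CN5CCN(C)CC5)cc4)cc23)c1` was examined in a functional assay on A-431 cells (Homo sapiens) for antiproliferative activity, read by MTT assay, with a stated time of 72 h (a lower number here means a stronger inhibitor, a higher number a weaker inhibitor), where compound 1 gives 2810 nM. Among the measured compounds shown here, of the two measured numbers this is the higher one; its only neighbour is compound 2 `COc1ccc(Nc2ncnc3ccc(NC(=O)Nc4ccc(CN5CCN(C)CC5)cc4)cc23)cc1Cl`, which in this assay gives 2010 nM. The step of a 1.4-fold lower number from compound 1 to compound 2 (0.15 log units; within the scatter) comes from 3-chloro-4-methoxyphenyl in place of 3-ethynylphenyl on a nitrogen on an aromatic ring, a change at a different site from the one considered here. Compound 3 `C#Cc1cccc(Nc2ncnc3ccc(NC(=O)Nc4ccc(CN(CC)CC)cc4)cc23)c1` differs from compound 1 by diethylamino in place of 4-methylpiperazin-1-yl on a saturated chain carbon bound to an aromatic carbon. For the measured compounds named here, no measured step touches this part of the molecule, and the single available step, which is within the scatter, concerns another position, so nothing in the present data points to a shift beyond the scatter in this assay. Compound 1 therefore serves as the anchor. Compound 3 is estimated at 2800 nM, with a range from 900 nM to 9000 nM. The expected step is a 1.0-fold lower number from compound 1 to compound 3 (0.00 log units; within the scatter).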

Compound 3, half-maximal inhibitory concentration: 1240 nM
Compound 3: middle estimate off by 2.3-fold (0.35 log units), on the high side; the measured number falls inside the stated range.
By their numbers in this assay, from the lowest: compounds 3, 2 and 1 (each within the scatter of the next, the first and the last beyond it).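

In this assay, the group on the saturated chain carbon bound to an aromatic carbon proves able to move the number: diethylamino in place of 4-methylpiperazin-1-yl gives a 2.3-fold lower number from compound 1 to compound 3 (0.36 log units; beyond the scatter), a modest step. The earlier change on the nitrogen on an aromatic ring stayed within the scatter, so this is the only listed step that lies beyond it. Nothing measured on these compounds accounts for the step.

On these data alone, it remains open whether the step follows from the loss of the ring or of its second nitrogen, a question that a piperidin-1-yl, morpholin-4-yl or dimethylamino group could help to separate. As far as these compounds go, it is also open whether diethylamino gives a similar step on the 3-chloro-4-methoxyphenyl background of compound 2.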